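Swapping chlorophenyl for propyl at the ether carbon

The source may report more compounds than this note shows. Statements on the series, on what has been measured and on what is new or still open speak of the compounds shown alone.

In a functional assay on the whole organism (strain C57B/6) with Mus musculus as the target, in the maximal electroshock model (a higher number here means that more compound is needed for the effect, a lower number that less compound is needed), compound 1 `CCc1nncn1-c1ccc(OCc2ccc(Cl)cc2)cc1` gives 19.7 mg/kg. Compound 2 `CCc1nncn1-c1ccc(OCc2ccccc2Cl)cc1` gives 13.2 mg/kg in this assay, the lower of the two numbers, although the step of a 1.5-fold lower number from compound 1 to compound 2 (0.17 log units; within the scatter) lies within the scatter. Compound 3 `CCCCOc1ccc(-n2cnnc2CC)cc1` differs from compound 2 in one place: propyl in place of 2-chlorophenyl on a saturated chain carbon bound to an oxygen on an aromatic ring. Among the compounds with values here, the single measured step only exchanged one chlorophenyl for another at that saturated chain carbon and changed little, so it bears only loosely on removing the aromatic ring altogether. Compound 3 is therefore expected to need somewhat more compound, a step of a 1.9-fold higher number from compound 2 to compound 3 (0.28 log units; within the scatter) in this assay, and is estimated at 25 mg/kg, within 10 mg/kg to 60 mg/kg.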

Compound 3, dose for half-maximal effect: > 100 mg/kg
Compound 3 ended at the assay's limit (the forecaster's own chance of this, stated with the estimate: 10%); middle value at least 4.0-fold (0.60 log units) from the limit.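

The value of compound 3 is a limit of the assay: the limit of > 100 mg/kg in this assay, at which 1 of the 3 values shown sits. Propyl in place of 2-chlorophenyl gives an at least 7.5-fold higher number from compound 2 to compound 3 (0.87 log units; beyond the scatter), and propyl in place of 4-chlorophenyl gives an at least 5.0-fold higher number from compound 1 to compound 3 (0.70 log units; beyond the scatter). Exchanging one chlorophenyl for the other stayed within the scatter, whereas replacing either with propyl at this saturated chain carbon lies beyond it, so the choice of group here matters in a way the first step did not show.

The compounds shown leave open whether the aromatic ring or the chlorine counts here. An unsubstituted phenyl, a cyclohexyl or a longer chain at this carbon would bear on that.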